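The source may hold more compounds than are shown below. What is called first, only, known or untested is meant among the compounds shown, and "the series" means these compounds.

Going by the values given here, compound 1 `O=C(Nc1cccc(-n2cc(-c3ccncc3)c(-c3ccc(Cl)c(O)c3)n2)c1)Nc1cc(C(F)(F)F)cc(C(F)(F)F)c1` is one of three compounds measured in a functional assay on T47D cells (Homo sapiens) for inhibition, read by sulforhodamine B assay, with a stated time of 48 h (a higher number here means a weaker inhibitor of growth, a lower number a stronger inhibitor of growth), where compound 1 gives 1820 nM. Compound 2 `COc1cc(-c2nn(-c3cccc(NC(=O)Nc4ccc(Cl)c(C(F)(F)F)c4)c3)cc2-c2ccncc2)ccc1Cl` gives 1230 nM and compound 3 `COc1cc(-c2nn(-c3cccc(NC(=O)c4ccccc4)c3)cc2-c2ccncc2)ccc1Cl` gives 1900 nM, so all three values lie within the scatter of one another. Compound 4 `O=C(Nc1cccc(-n2cc(-c3ccncc3)c(-c3ccc(Cl)c(O)c3)n2)c1)Nc1cccc(C(F)(F)F)c1` differs from compound 1 in one place: hydrogen in place of trifluoromethyl on an aromatic carbon. Among the compounds with values here, the only measured step, a 1.5-fold higher number from compound 2 to compound 3 (0.19 log units; within the scatter), concerns a change on a carbonyl carbon, not the trifluoromethyl group, so nothing measured bears directly on this change. With no guidance from the measured compounds, no step beyond the scatter is expected. Compound 4 is therefore estimated at 2000 nM, between 700 nM and 6000 nM, an expected step of a 1.1-fold higher number from compound 1 to compound 4 (0.04 log units; within the scatter).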

Compound 4, concentration for 50% growth inhibition: 2470 nM
Beside the measured number, compound 4's estimate is 1.2-fold (0.09 log units) below it, within the range that was stated.
By their numbers in this assay, from the lowest: compounds 2, 1, 3 and 4 (each within the scatter of the next).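

Replacing one of the two trifluoromethyl groups on this aromatic ring with hydrogen gives a 1.4-fold higher number from compound 1 to compound 4 (0.13 log units; within the scatter) in this assay. Going by these compounds alone, this is the first measured change at this position, and it shows that, in this assay, losing this trifluoromethyl group leaves growth inhibition within the scatter. No measurement here gives a reason for this result. On these data alone, it remains open whether an amine or a carboxylic acid at this position would give a step beyond the scatter. As far as these compounds go, replacing the remaining trifluoromethyl group with hydrogen is equally open.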